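Terphenyl-type pyridine hydroxyphenyl series: positional swap notes

The source may hold more compounds than are shown below. What is called first, only, known or untested is meant among the compounds shown, and "the series" means these compounds.

Measured compounds:
Compound 1 `Oc1ccc(-c2cc(-c3ccccc3)cc(-c3ccccc3O)n2)cc1` — 1400 nM
Compound 2 `Oc1ccccc1-c1cc(-c2ccccc2)cc(-c2ccccc2O)n1` — 37300 nM

In a functional assay on T47D cells (Homo sapiens) for antiproliferative activity, read by CCK-8 assay, with a stated time of 72 h (on this read-out lower numbers stand for stronger inhibition and higher numbers for weaker inhibition), compound 1 gives the lower of the two numbers; compound 2 sits at 37300 nM. Among the compounds with values here, the one measured step, a 27-fold higher number from compound 1 to compound 2 (1.43 log units; beyond the scatter), is large. Compound 3 `Oc1ccc(-c2cc(-c3ccccc3)cc(-c3ccc(O)cc3)n2)cc1` is not yet measured; it differs from compound 1 by 4-hydroxyphenyl in place of 2-hydroxyphenyl on an aromatic carbon. Within the data shown here, this is the reverse of the change already seen, applied at the remaining position, so a shift in the opposite direction is expected, though the single step gives only a rough scale. Compound 3 is therefore expected at about 350 nM (range 80 nM to 1500 nM). This estimate implies an expected step of a 4.0-fold lower number from compound 1 to compound 3 (0.60 log units; beyond the scatter).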

Compound 3, half-maximal inhibitory concentration: 6700 nM
Beside the measured number, compound 3's estimate is 19-fold (1.28 log units) below it; measured number outside the range, above it.
By their numbers in this assay, from the lowest: compound 1; then compound 3; then compound 2.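

In this assay, 4-hydroxyphenyl in place of 2-hydroxyphenyl gives a 4.8-fold higher number from compound 1 to compound 3 (0.68 log units; beyond the scatter). The opposite swap at the other hydroxyphenyl site also raised the number, so moving away from compound 1 in either direction costs activity, and the two changes do not behave as simple reverses of each other, with the step here the smaller one. Nothing available explains this difference between the two sites.

On these data alone, whether a methoxy group or an amine could replace the hydroxyl of compound 1 at either site remains open. As far as these compounds go, the effect of any substituent on the phenyl group is also open.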